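Replacing the acrylamide tail on the core of compound 1

A few compounds are considered here, and "the series" means these few. Any claim that something is new, unique, unknown or untested is made for them only; others in the source may bear on it.

Three compounds sharing one core have been examined in a functional assay on PC-3 cells (Homo sapiens) for antiproliferative activity, read by MTT assay, with a stated time of 72 h; a higher number here means a weaker inhibitor, a lower number a stronger inhibitor. Compound 1 `COc1cc2ncnc(N3CCc4ccccc43)c2cc1NC(=O)C=C(C)C` gives 7840 nM in this assay. Compound 2 `CCC/C=C/C(=O)Nc1cc2c(N3CCc4ccccc43)ncnc2cc1O[C@@H]1CCOC1` gives 9230 nM in this assay, and compound 3 `CC(C)=CC(=O)Nc1cc2c(N3CCCc4ccccc43)ncnc2cc1O[C@@H]1CCOC1` gives 9020 nM. The number of compound 1 is the lowest of the three, but both neighbours lie within the scatter of it, so no order among them can be claimed. Compound 4 `COc1cc2ncnc(N3CCc4ccccc43)c2cc1NC(=O)/C=C/CN1CCN(C)CC1` has not yet been measured; it differs from compound 1 by 3-(4-methylpiperazin-1-yl)prop-1-en-1-yl in place of 2-methylprop-1-en-1-yl on a carbonyl carbon. For the measured compounds named here, no measured pair shows this change, so its size is unknown from the data. Compound 4 is expected to give a somewhat lower number, a step of a 2.0-fold lower number from compound 1 to compound 4 (0.29 log units; within the scatter) that may still fall within the scatter. The estimate for compound 4 is 4000 nM, within a range from 1500 nM to 12000 nM.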

Compound 4, half-maximal inhibitory concentration: 9180 nM
The estimate for compound 4 lay 2.3-fold (0.36 log units) below the measured number; the range from low to high includes it.
By their numbers in this assay, from the lowest: compounds 1, 3, 4 and 2 (each within the scatter of the next).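

In this assay, the change at this carbonyl carbon, the first one measured there, gives a 1.2-fold higher number from compound 1 to compound 4 (0.07 log units; within the scatter) and so stays within the scatter. Thus 3-(4-methylpiperazin-1-yl)prop-1-en-1-yl, which brings a six-membered non-aromatic ring and two nitrogen atoms, leaves the number where 2-methylprop-1-en-1-yl had it. Nothing measured here bears on why the number holds. Going by these compounds, whether a tail ending in a dimethylamine, a morpholine or a carboxylic acid would read differently remains open. So does whether the same exchange would read alike on compound 2 or compound 3.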